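Allylic hydroxyl on a phenoxy side chain: expected potency

The compounds below may be only part of what the source reports. "The series", "measured", "known", "first", "only" and "open" are said of these compounds alone.

Measured compounds:
compound 1 `O=C(O)c1csc([C@H]2CC[C@@H]3[C@@H](/C=C/COc4ccccc4)[C@H](O)C[C@@H]3O2)n1`, 700 nM
compound 2 `O=C(O)c1csc([C@H]2CC[C@@H]3[C@@H](/C=C/CCCOc4ccccc4)[C@H](O)C[C@@H]3O2)n1`, 970 nM
compound 3 `O=C(O)c1csc([C@H]2CC[C@@H]3[C@@H](COc4ccccc4)[C@H](O)C[C@@H]3O2)n1`, a limit, > 10000 nM

Three compounds share the core of compound 2 and differ only in the side chain. In a functional assay on CHO cells for agonist activity at prostaglandin E2 receptor EP1 subtype (Homo sapiens), read by fluorescence and calcium flux (a lower number here means that less compound is needed, a higher number that more compound is needed for the effect), compound 1 gives 700 nM. Compound 2, which carries 2-phenoxyethyl in place of phenoxy on a saturated chain carbon bound to a double-bonded chain carbon, gives 970 nM in this assay; the step of a 1.4-fold higher number from compound 1 to compound 2 (0.14 log units; within the scatter) is within the scatter, so the two stand level. Compound 2 holds the highest of the two numbers given, with compound 1 as its nearest neighbour. Compound 3 reaches only a limit in this assay, > 10000 nM, and the limit of > 10000 nM in this assay, at which 1 of the 3 values shown sits, is where that value sits.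

The compound not yet measured is compound 4 `O=C(O)c1csc([C@H]2CC[C@@H]3[C@@H](/C=C/[C@@H](O)COc4ccccc4)[C@H](O)C[C@@H]3O2)n1`. It differs from compound 2 by 1-hydroxy-2-phenoxyethyl in place of 3-phenoxypropyl on a double-bonded chain carbon bound to a double-bonded chain carbon. For the measured compounds named here, the one measured step, a 1.4-fold higher number from compound 1 to compound 2 (0.14 log units; within the scatter), changes the length of the phenoxy-bearing chain and is within the scatter; no measured step introduces a hydroxyl on the chain, so the new hydroxyl and stereocentre have no precedent here. The shortening of the chain by itself is expected to be of little effect, and the estimate for compound 4 is therefore 500 nM, with a range from 100 nM to 2500 nM, which is expected to mean a step of a 1.9-fold lower number from compound 2 to compound 4 (0.29 log units; within the scatter) in this assay.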

Compound 4, half-maximal effective concentration: 1.4 nM
Estimate against measurement, compound 4: 360-fold (2.55 log units) above; the measured number lies below the stated range.
By their numbers in this assay, from the lowest: compound 4; then compounds 1 and 2 (each within the scatter of the next). At a limit, above all of these: compound 3.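

The side chain on this double-bonded chain carbon, where a change of length alone stayed within the scatter, proves highly sensitive to what it carries: in this assay, 1-hydroxy-2-phenoxyethyl in place of 3-phenoxypropyl gives a 690-fold lower number from compound 2 to compound 4 (2.84 log units; beyond the scatter) and, in place of phenoxymethyl, gives a 500-fold lower number from compound 1 to compound 4 (2.70 log units; beyond the scatter) as a second large step. The phenyl ether survives the change from 3-phenoxypropyl, and the entering group differs in carrying a hydrogen-bond donor and a defined stereocentre, neither of which the leaving group has. Nothing measured here accounts for the size of this gain.

Going by these compounds, whether the hydroxyl itself or its configuration matters more stays open, as does whether a methoxy group, a carbonyl or an amine on that same chain carbon, or the opposite configuration there, would hold the number. On these data alone, it is also open whether a longer chain beyond the hydroxyl-bearing carbon would keep the gain, and whether the gain extends to other prostaglandin receptor subtypes.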